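A few compounds are considered here, and "the series" means these few. Any claim that something is new, unique, unknown or untested is made for them only; others in the source may bear on it.

Compound 3 `COc1cc(-n2ncnc2-c2ccc(C)cc2)cc(OC)c1OC` gives 300 nM in a functional assay on Jurkat cells (Homo sapiens) for antiproliferative activity, read by MTT assay, with a stated time of 72 h (a higher number here means a weaker inhibitor, a lower number a stronger inhibitor), the lowest of the two numbers reported; the nearest is compound 1 `COc1cc(-n2ncnc2-c2ccc(OC(C)C)cc2)cc(OC)c1OC`, which gives 650 nM in this assay. Compound 2 `COc1cc(-c2ncnn2-c2ccccc2)cc(OC)c1OC` returns only a limit in this assay, > 10000 nM. Among the compounds with values here, the single measured step on this aryl group, a 2.2-fold lower number from compound 1 to compound 3 (0.34 log units; beyond the scatter), is modest. Compound 4 `COc1cc(-n2ncnc2-c2ccc(Cl)c(Cl)c2)cc(OC)c1OC` carries the change (3,4-dichlorophenyl in place of 4-methylphenyl on an aromatic carbon). Within the data shown here, no measured step covers a move to 3,4-dichlorophenyl; the one step known is a weak guide, and a change of comparable size, in either direction, is the expectation in this assay. Compound 4 is therefore expected at about 250 nM, within 80 nM to 800 nM. The step this implies, a 1.2-fold lower number from compound 3 to compound 4 (0.08 log units; within the scatter), is expected to sit near the scatter.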

Compound 4, half-maximal inhibitory concentration: > 10000 nM
Compound 4: no number, only a limit; the forecaster's own chance of this, stated with the estimate: 5%; middle value at least 40-fold (1.60 log units) away from the limit.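

On the aromatic carbon between two ring nitrogen atoms, 3,4-dichlorophenyl in place of 4-methylphenyl gives an at least 33-fold higher number from compound 3 to compound 4 (1.52 log units; beyond the scatter), whereas the earlier step on this aryl group was only a 2.2-fold lower number from compound 1 to compound 3 (0.34 log units; beyond the scatter). Changes at this position in this assay are therefore not limited to modest shifts, and one change of aryl group can take the reading out of the measured range. Compound 4 gives only a limit, so the full size of the step stays unknown, and that limit recurs in the series: the limit of > 10000 nM in this assay, at which 2 of the 4 values shown sit.

On these data alone, it remains open whether a single chlorine on the phenyl ring keeps the reading within the measured range. As far as these compounds go, the effect of a methoxy group or an amine there also remains open.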